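The compounds below may be only part of what the source reports. "The series", "measured", "known", "first", "only" and "open" are said of these compounds alone.

Working notes on the series, all read in a functional assay on CLL cells (Homo sapiens) for cytotoxicity, read by MTT assay, with a stated time of 48 h; a higher number here means that more compound is needed for the effect, a lower number that less compound is needed. Compound 1 (`C=C(CC)C(=O)c1ccc(OCC(=O)Nc2ccc(C(=O)O)c(O)c2)c(Cl)c1Cl`) returns only a limit and no number, > 25000 nM. Compound 2 (`C=C(CC)C(=O)c1ccc(OCC(=O)Nc2ccc(C(=O)NC(CCC(=O)OCC)C(=O)OCC)cc2)c(Cl)c1Cl`) gives 2100 nM. Compound 3 (`C=C(CC)C(=O)c1ccc(OCC(=O)Nc2ccc(/C=C/C(=O)NO)cc2)c(Cl)c1Cl`) gives 2600 nM, which lies within the scatter of the value for compound 2, so the two stand level.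

The next compound is compound 4 (`C=C(CC)C(=O)c1ccc(OCC(=O)Nc2ccc(C(=O)OC)cc2)c(Cl)c1Cl`). The change is methoxycarbonyl in place of 2-(hydroxycarbamoyl)ethenyl on an aromatic carbon, para to a large group. For the measured compounds named here, no measured pair differs in one place only, so this change has no direct precedent in this assay. The working expectation is no step beyond the scatter, with any drift toward a higher number. It rests on compound 2 at 2100 nM and compound 3 at 2600 nM, which carry different groups at this place and still sit together. Compound 1 goes against this reading, so the range is kept wide on the high side. The expected size of the change is a 1.3-fold higher number from compound 3 to compound 4 (0.13 log units; within the scatter), which is estimated to stay within the scatter. For compound 4 the estimated value is 3500 nM, with an expected range of 1300 nM to 10000 nM.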

Compound 4, half-maximal effective concentration: 4100 nM
Estimate against measurement, compound 4: 1.2-fold (0.07 log units) below; the measured number falls inside the stated range.
By their numbers in this assay, from the lowest: compounds 2, 3 and 4 (each within the scatter of the next). At a limit, above all of these: compound 1.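

In this assay the series now has its first step that differs in one place only: a 1.6-fold higher number from compound 3 to compound 4 (0.20 log units; within the scatter), with methoxycarbonyl in place of 2-(hydroxycarbamoyl)ethenyl on an aromatic carbon, para to a large group. At this place, a group with 2 hydrogen-bond donors and 2 double bonds outside aromatic rings gives way to one with 0 hydrogen-bond donors and 1 such double bond, and the step stays within the scatter, so for compound 3 and compound 4 the read-out does not depend on the 2-(hydroxycarbamoyl)ethenyl group. Compound 1 remains a limit and not a number, and it differs from compound 4 in more than one place, so it supplies no step at this position: the limit of > 25000 nM in this assay, at which 1 of the 4 values shown sits.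

Still open, as far as these compounds go, is whether the flat reading at this place extends to groups of another kind, such as an amine or a longer alkyl chain, in place of methoxycarbonyl on the shared core. A single step also leaves open whether the same exchange would stay within the scatter with any other change elsewhere on the core.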